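The source may hold more compounds than are shown below. What is called first, only, known or untested is meant among the compounds shown, and "the series" means these compounds.

Compound 3 `O=C(CN1CCC(c2cccc[n+]2[O-])CC1)Nc1cccc(F)c1` is one of three compounds sharing a core, the others being compound 1 `O=C(CN1CCC(c2cccc[n+]2[O-])CC1)NC1CCCCC1` and compound 2 `CCc1cccc(NC(=O)CN2CCC(c3cccc[n+]3[O-])CC2)c1`. In a functional assay on HEK293 cells for agonist activity at D(4) dopamine receptor (Homo sapiens), read by FLIPR (a lower number here means that less compound is needed, a higher number that more compound is needed for the effect), compound 1 gives 294 nM, compound 2 gives 95 nM, and compound 3 gives 160 nM. Compound 3 therefore stands second highest of the three; its nearest neighbour is compound 2, and a 1.7-fold higher number from compound 2 to compound 3 (0.23 log units; within the scatter), while a 1.8-fold lower number from compound 1 to compound 3 (0.26 log units; within the scatter). Within the data shown here, only one measured step clears the scatter: a 3.1-fold lower number from compound 1 to compound 2 (0.49 log units; beyond the scatter).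

Compound 4 `Cc1cc(Br)ccc1NC(=O)CN1CCC(c2cccc[n+]2[O-])CC1` has not yet been measured. Its difference from compound 3 is 4-bromo-2-methylphenyl in place of 3-fluorophenyl on an amide-type nitrogen. Among the measured compounds shown here, the steps that bear on it are the two changes on the amide-type nitrogen among measured compounds: the exchange of the group on the aromatic carbon, a 1.7-fold higher number from compound 2 to compound 3 (0.23 log units; within the scatter), and the exchange of cyclohexyl for an aryl group, a 1.8-fold lower number from compound 1 to compound 3 (0.26 log units; within the scatter). For the measured compounds named here, neither reaches beyond the scatter, and no measured compound carries bromo or methyl on that ring. Compound 4 is thus expected to give about 150 nM in this assay, with a range from 60 nM to 400 nM. The expected step is a 1.1-fold lower number from compound 3 to compound 4 (0.03 log units; within the scatter), not beyond the scatter.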

Compound 4, half-maximal effective concentration: 66 nM
Compound 4: the middle estimate sits 2.3-fold (0.36 log units) above what was measured; the measured number falls inside the stated range.
By their numbers in this assay, from the lowest: compounds 4, 2, 3 and 1 (each within the scatter of the next, the first and the last beyond it).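

Among the aryl groups on the amide-type nitrogen, 4-bromo-2-methylphenyl gives the first aryl-for-aryl exchange in this assay that clears the scatter, a 2.4-fold lower number from compound 3 to compound 4 (0.38 log units; beyond the scatter), whereas the exchange of 3-ethylphenyl for 3-fluorophenyl did not. Against 3-ethylphenyl the new group stays inside the scatter, a 1.4-fold lower number from compound 2 to compound 4 (0.16 log units; within the scatter), so the two substituted phenyl groups cannot be told apart here. Replacing cyclohexyl with 4-bromo-2-methylphenyl gives a 4.5-fold lower number from compound 1 to compound 4 (0.65 log units; beyond the scatter), a second aryl exchange for cyclohexyl beyond the scatter, alongside 3-ethylphenyl, while 3-fluorophenyl stays within it.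

Nothing available accounts for these steps. Bromo and methyl enter together, so their separate contributions remain open, as does the outcome with a carboxylic acid or an amine on that ring.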